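Shortening a Chain on Two Related Cores

A few compounds are considered here, and "the series" means these few. Any claim that something is new, unique, unknown or untested is made for them only; others in the source may bear on it.

Compound 1 has the structure `CCCCCSc1nc(NCc2ccc([Se]C)cc2)c2ccccc2n1`. In a functional assay on HT-29 cells (Homo sapiens) for cytotoxicity, read by MTT assay, with a stated time of 72 h (on this read-out higher numbers stand for lower toxicity in this test and lower numbers for higher toxicity in this test), compound 1 gives only a limit of the assay, > 100000 nM. Compound 2, with the structure `CSc1nc(NCc2ccc([Se]C)cc2)c2ccccc2n1`, is its close relative; in this assay compound 2 likewise gives only a limit, > 100000 nM. The change between them is hydrogen in place of butyl on a saturated chain carbon bound to a sulfur, and the step it made is a step that the two limits leave unreadable from compound 1 to compound 2. What the two values share is the limit of > 100000 nM in this assay, at which 2 of the 3 values shown sit, so the size of that step cannot be read from them.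

Compound 3 has the structure `CCCCC[Se]c1nc(N)c2cccnc2n1`. In this assay, among the compounds with values here, compound 3 gives 62100 nM, the only number among the three measured values. How the core of compound 3 differs from the core of compound 1 is not broken down here.

Compound 4, with the structure `C[Se]c1nc(N)c2cccnc2n1`, has not yet been measured. It differs from compound 3 by hydrogen in place of butyl on a saturated chain carbon bound to a selenium atom. This is the same kind of change as that from compound 1 to compound 2, but the place differs: there the chain carbon is bound to a sulfur, here it is bound to a selenium atom.

Since the earlier step left no readable size, the expectation for compound 4 rests on the value of compound 3, 62100 nM, and is an estimated step of a 1.3-fold higher number from compound 3 to compound 4 (0.11 log units; within the scatter). Compound 4 is therefore expected to give about 80000 nM in this assay, within a range estimated from 30000 nM to 200000 nM.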

Compound 4, concentration lethal to 50% of the cells: > 100000 nM
Compound 4: only a limit was reported; the forecaster's own chance of this, stated with the estimate: 40%; at least 1.2-fold (0.09 log units) between middle value and limit.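

In this assay, the change of hydrogen in place of butyl on a saturated chain carbon bound to a selenium atom gives an at least 1.6-fold higher number from compound 3 to compound 4 (0.20 log units; that floor lies within the scatter); this is only a floor, resting on a limit of the assay, and it lies within the usual scatter, so it does not establish a real change on this core. What it does show is that the shortened compound on this core ends up at the same limit as the two compounds on the core of compound 1, which is all that can be said of carrying the change across. It does not show that the change acts alike on both cores, since neither step has a full size to compare, and the steps cannot be read because so many values are limits: the limit of > 100000 nM in this assay, at which 3 of the 4 values shown sit.

From the compounds shown here alone, it remains open whether a propyl chain in the same place, or a carboxylic acid at the end of the pentyl chain, would give a measured number rather than a limit. Also open, going by these compounds, is whether swapping the selenium atom for a sulfur on the core of compound 3 would matter on its own.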